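Acetylating a Free Hydroxy Group: Compound 2 to Compound 4

The source may hold more compounds than are shown below. What is called first, only, known or untested is meant among the compounds shown, and "the series" means these compounds.

compound 1 `C/C=C(\C)C(=O)O[C@H]1C[C@@]2(C)O[C@H]2[C@@H](OC(C)=O)[C@@]2(C)CC[C@@](O)(C(C)C)[C@H]12` — > 100000 nM
compound 2 `COc1ccc(C(=O)O[C@H]2CC(C)=C[C@H](O)[C@@]3(C)[C@@H](OC(C)=O)C[C@@](O)(C(C)C)[C@H]23)cc1` — 5900 nM
compound 3 `C/C=C(/C)C(=O)O[C@H]1CC(C)=C[C@@H](OC(=O)/C(C)=C\C)[C@@]2(C)CC[C@@](O)(C(C)C)[C@H]12` — 7700 nM

In a functional assay on Jurkat cells (Homo sapiens) for cytotoxicity, read by MTT assay, with a stated time of 72 h (a higher number here means a weaker inhibitor, a lower number a stronger inhibitor), compound 1 gives > 100000 nM, which is a limit of the assay rather than a number (the limit of > 100000 nM in this assay, at which 1 of the 3 values shown sits). Compound 2 gives 5900 nM in this assay. Compound 3 gives 7700 nM, and the two numbers lie within the scatter of each other, so compound 2 cannot be set apart from compound 3. Compound 4 `COc1ccc(C(=O)O[C@H]2CC(C)=C[C@H](OC(C)=O)[C@@]3(C)[C@@H](OC(C)=O)C[C@@](O)(C(C)C)[C@H]23)cc1` differs from compound 2 in one place: acetyl in place of hydrogen on an oxygen on a saturated carbon. For the measured compounds named here, no measured pair shows this change, so nothing here points to a shift beyond the scatter. Compound 4 is expected to give 6000 nM in this assay, within 2500 nM to 15000 nM. The expected step of a 1.0-fold higher number from compound 2 to compound 4 (0.01 log units; within the scatter) is thus no larger than the usual scatter.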

Compound 4, half-maximal inhibitory concentration: 3300 nM
Beside the measured number, compound 4's estimate is 1.8-fold (0.26 log units) above it, and the stated range covers the measured number.
By their numbers in this assay, from the lowest: compounds 4, 2 and 3 (each within the scatter of the next, the first and the last beyond it). At a limit, above all of these: compound 1.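

Going from hydroxy to acetoxy on this oxygen gives a 1.8-fold lower number from compound 2 to compound 4 (0.25 log units; within the scatter) in this assay, so compound 2 and compound 4 cannot be set apart. In this one pair, the free hydroxy hydrogen at this position is therefore not needed for the cytotoxicity seen, and the added acetyl is tolerated. No measurement shown here speaks to what lies behind this result.

Going by these compounds, it remains open whether a longer chain, such as hexanoyl, or a group carrying an amine would be tolerated on this oxygen. On these data alone, it also remains open whether the same change would behave alike on another core.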